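Chain extension at the furan carbon in the cytotoxicity series

A few compounds are considered here, and "the series" means these few. Any claim that something is new, unique, unknown or untested is made for them only; others in the source may bear on it.

Measured so far:
- compound 1, `CCCCc1cc2cn(COCCO)c(=O)nc2o1` — > 400000 nM
- compound 2, `CCCCCc1cc2cn(COCCO)c(=O)nc2o1` — > 400000 nM

Both values are limits of a functional assay on HEL cells (Homo sapiens), read by microscopy (on this read-out lower numbers stand for higher toxicity in this test and higher numbers for lower toxicity in this test), not numbers. In this assay compound 1 reaches only the limit > 400000 nM. In the same assay compound 2 also reaches only the limit > 400000 nM. The step that the two limits leave unreadable from compound 1 to compound 2 is therefore unreadable; both values sit at the limit of > 400000 nM in this assay, at which 2 of the 2 values shown sit, and nothing in the series shows where either compound would stand if the assay extended further.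

Compound 3, `CCCCCCCCc1cc2cn(COCCO)c(=O)nc2o1`, carries the change (propyl in place of hydrogen on a saturated chain carbon, five bonds along the chain from an aromatic carbon). Among the compounds with values here, no measured step bears directly on it; the only step, from compound 1 to compound 2, is itself unreadable. Compound 2 stands at the limit, and the expectation for compound 3 is that it too will most likely sit at the limit, with the step of a number no higher from compound 2 to compound 3 (the limit leaves the size open) expected to be small. Compound 3 is estimated at 400000 nM, within 100000 nM to 800000 nM, and the result is expected to be reported as a limit more often than as a number.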

Compound 3, minimum cytotoxic concentration: >= 80000 nM
Compound 3: a limit, no number; the forecaster's own chance of this, stated with the estimate: 65%; the middle value does not contradict the limit.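

The values of compound 1, compound 2 and compound 3 are all limits and not numbers, so no step among these compounds can be read. The compounds shown leave open where any of the three would stand as a number, and whether the longer chain of compound 3 changes the read-out at all.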